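A few compounds are considered here, and "the series" means these few. Any claim that something is new, unique, unknown or untested is made for them only; others in the source may bear on it.

Compound 1 `O=C(O)C[C@@H](NC(=O)[C@@H]1CCN1S(=O)(=O)c1cc(Cl)cc(Cl)c1)c1ccc(OC(F)F)cc1`; compound 2 `O=C(O)C[C@@H](NC(=O)[C@@H]1CCN1S(=O)(=O)c1cc(Cl)cc(Cl)c1)c1ccc(Br)cc1`.

In an assay on RPMI-8866 cells for inhibition of integrin alpha-4/beta-1 (Homo sapiens) (a lower number here means a stronger inhibitor, a higher number a weaker inhibitor), compound 1 gives 1.3 nM and compound 2 gives 2.1 nM. Compound 2 stands alongside compound 1 rather than apart from it, since the step of a 1.6-fold higher number from compound 1 to compound 2 (0.21 log units; within the scatter) lies within the scatter. Compound 3 `O=C(O)C[C@@H](NC(=O)[C@@H]1CCN1S(=O)(=O)c1cc(Cl)cc(Cl)c1)c1ccc(OCF)cc1` differs from compound 2 by fluoromethoxy in place of bromo on an aromatic carbon. For the measured compounds named here, the one measured step that bears on this change, a 1.6-fold higher number from compound 1 to compound 2 (0.21 log units; within the scatter), was small, and fluoromethoxy is close to the difluoromethoxy of compound 1. A step of a 1.3-fold lower number from compound 2 to compound 3 (0.12 log units; within the scatter) is therefore expected, nothing beyond the scatter. Compound 3 is estimated at 1.6 nM, ranging from 0.6 nM to 4.5 nM.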

Compound 3, half-maximal inhibitory concentration: 0.72 nM
Beside the measured number, compound 3's estimate is 2.2-fold (0.35 log units) above it; measured number inside the range.
By their numbers in this assay, from the lowest: compounds 3, 1 and 2 (each within the scatter of the next, the first and the last beyond it).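

In this assay, the step of a 2.9-fold lower number from compound 2 to compound 3 (0.46 log units; beyond the scatter) shows that the group at this position on the aromatic ring can shift the number beyond the scatter, though only modestly. The step of a 1.8-fold lower number from compound 1 to compound 3 (0.26 log units; within the scatter) stays within the scatter, so fluoromethoxy and difluoromethoxy cannot be told apart here. Nothing available explains the gap between fluoromethoxy and bromo. From the compounds shown here alone, what a plain methoxy, a longer chain such as ethoxy, or an amine would give at this position remains open.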